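This account rests on a few compounds, and the source may have more. Where it says the series, first, only, none or still open, it means among the compounds named here.

Compound 1 `O=C(NNc1ccnc2cc(Cl)ccc12)c1ccccc1/N=C/c1ccc(Cl)cc1` gives 5.62 in a physicochemical assay for lipophilicity, measured as octanol-water partition; on this read-out higher numbers stand for higher lipophilicity and lower numbers for lower lipophilicity. Compound 2 `O=C(NNc1ccnc2cc(Cl)ccc12)c1ccccc1/N=C/c1cccc(Cl)c1Cl` gives 6.1. Compound 3 `O=C(NNc1ccnc2cc(Cl)ccc12)c1ccccc1/N=C/c1ccc(Br)cc1` gives 5.76.

Compound 3 stands second highest of these three numbers: compound 1 is its nearest neighbour, with a step of a number 0.14 log units higher from compound 1 to compound 3 (within the scatter), while compound 2 is furthest away, with a step of a number 0.34 log units lower from compound 2 to compound 3 (beyond the scatter). Compound 4 `O=C(NNc1ccnc2cc(Cl)ccc12)c1ccccc1/N=C/C=C/c1ccccc1` has not yet been measured. Its change from compound 3 is 2-phenylethenyl in place of 4-bromophenyl on a carbon with a double bond to nitrogen. Within the data shown here, none of the measured steps exchanges a halogenated phenyl for a 2-phenylethenyl group; the measured steps only swap halogens, and they were a number 0.48 log units higher from compound 1 to compound 2 (beyond the scatter) and a number 0.14 log units higher from compound 1 to compound 3 (within the scatter). A group of about the same size enters, so no step beyond the scatter is expected, and the estimated step is a number 0.16 log units lower from compound 3 to compound 4 (within the scatter). Compound 4 is therefore expected to give about 5.6, between 5.2 and 6.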

Compound 4, partition coefficient: 5.54
Compound 4: middle estimate off by 0.06 log units, on the high side; the measured number falls inside the stated range.
By their numbers in this assay, from the lowest: compounds 4, 1 and 3 (each within the scatter of the next); then compound 2.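

In this assay, 2-phenylethenyl, which carries no halogen, cannot be told apart from either single-halogen phenyl group at this carbon with a double bond to nitrogen (from 4-bromophenyl: a number 0.22 log units lower from compound 3 to compound 4 (within the scatter); from 4-chlorophenyl: a number 0.08 log units lower from compound 1 to compound 4 (within the scatter)). Only 2,3-dichlorophenyl stands clearly apart (a number 0.56 log units lower from compound 2 to compound 4 (beyond the scatter)). Nothing available explains these numbers.

Still open, from the compounds shown here alone, is whether a group without a ring, such as a longer carbon chain, would give a number in the same range. The same question applies to a phenyl ring carrying an amine or a carboxylic acid.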